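The source may hold more compounds than are shown below. What is called first, only, known or untested is meant among the compounds shown, and "the series" means these compounds.

Measured in a functional assay on RS4-11 cells (Homo sapiens) for inhibition, read by CCK-8 assay, with a stated time of 48 h, tested at 20 uM; a higher number here means more inhibition of growth at the concentration tested, a lower number less inhibition of growth:
compound 1 `COc1ccc(Cc2nnc(NC(=O)/C(C#N)=C/c3ccccc3OS(=O)(=O)c3ccc(F)cc3)s2)cc1`: 80%
compound 2 `N#C/C(=C\c1ccccc1OS(=O)(=O)c1ccc(F)cc1)C(=O)Nc1nnc(Cc2cccc3ccccc23)s1`: 68%
compound 3 `COc1ccc(S(=O)(=O)Oc2ccccc2/C=C(\C#N)C(=O)Nc2nnc(Cc3cccc(F)c3)s2)cc1`: 74%

Compound 3 gives 74%, which lies within the scatter of each of the other two measured compounds. Compound 4 `N#C/C(=C\c1ccccc1OS(=O)(=O)c1ccc(F)cc1)C(=O)Nc1nnc(Cc2cccc(F)c2)s1` departs from compound 3 at one place: fluoro in place of methoxy on an aromatic carbon. Read one bond further out, this is 4-methoxyphenyl to 4-fluorophenyl. Among the measured compounds shown here, no measured step isolates this change. For the measured compounds named here, the only step available is a number 12 percentage points lower from compound 1 to compound 2 (beyond the scatter), and it concerns a different place in the structure, so it says little about the size of this one. Some indirect support comes from the (4-fluorophenyl)sulfonyl group itself, which compound 1 carries at 80% and compound 2 carries at 68%. Substantial inhibition is therefore seen with this group, at values on either side of that of compound 3. Accordingly, no change beyond the scatter is expected in this assay. The expected size is no change at the digits printed from compound 3 to compound 4 (within the scatter). For compound 4 the estimated value is 74%, with an expected range from 60% to 86%.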

Compound 4, percent growth inhibition at one concentration: 72%
Compound 4: the middle estimate sits 2 percentage points above what was measured, and the stated range covers the measured number.
By their numbers in this assay, from the lowest: compounds 2, 4, 3 and 1 (each within the scatter of the next, the first and the last beyond it).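

Among the compounds shown here, exchanging (4-methoxyphenyl)sulfonyl for (4-fluorophenyl)sulfonyl gives the first direct reading at this position: in this assay there is a number 2 percentage points lower from compound 3 to compound 4 (within the scatter), so with 3-fluorophenyl on the saturated chain carbon, methoxy and fluoro cannot be told apart here. With the (4-fluorophenyl)sulfonyl group held, the new compound also sits within the scatter of both neighbours, with a number 4 percentage points higher from compound 2 to compound 4 (within the scatter) and a number 8 percentage points lower from compound 1 to compound 4 (within the scatter), although a number 12 percentage points lower from compound 1 to compound 2 (beyond the scatter) separates those two chain substituents from each other. No measurement shown bears on why these steps are as small as they are.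

The methoxy and fluoro pair is shown with 3-fluorophenyl only, so it remains open whether the exchange reads alike with naphthalen-1-yl or 4-methoxyphenyl on the chain carbon. From the compounds shown here alone, it is also open how an amine or a carboxylic acid would read in place of methoxy or fluoro.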